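A few compounds are considered here, and "the series" means these few. Any claim that something is new, unique, unknown or untested is made for them only; others in the source may bear on it.

Going by the values given here, compound 1 `O=c1c(O)c(O)oc2ccc(Cl)cc12` is the one member of this small set that yields a number in a functional assay on the whole organism for inhibition, with Homo sapiens as the target; on this read-out higher numbers stand for weaker inhibition and lower numbers for stronger inhibition: in this assay compound 1 gives 1130000 nM. Compound 2 `O=C1C(O)=C(O)OC12CCCC2` reaches only a limit of the assay, > 4000000 nM. Compound 3 `O=C1C(O)=C(O)OC12CCCCC2` likewise ends at a limit, > 4000000 nM. Compound 1 therefore stands alone with a measured value, the other two sitting at the limit of > 4000000 nM in this assay, at which 2 of the 3 values shown sit. Compound 4 `O=c1c(O)c(O)oc2ccc(O)cc12` differs from compound 1 in one place: hydroxy in place of chloro on an aromatic carbon. Among the compounds with values here, no step between measured compounds covers this change. Compound 4 is expected to land close to compound 1, the step of a 1.8-fold higher number from compound 1 to compound 4 (0.25 log units; within the scatter) being a modest shift toward weaker inhibition that may not exceed the scatter. In this assay compound 4 is thus estimated at 2000000 nM, within 600000 nM to 6000000 nM.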

Compound 4, half-maximal inhibitory concentration: 3410000 nM
Compound 4: middle estimate off by 1.7-fold (0.23 log units), on the low side; low and high end bracket the measured number.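

In this assay, going by these compounds alone, the first readable change at this aromatic carbon shows that the group there matters: hydroxy in place of chloro gives a 3.0-fold higher number from compound 1 to compound 4 (0.48 log units; beyond the scatter), a shift toward weaker inhibition that lies beyond the scatter. Of these two groups, chloro therefore gives the stronger inhibition at this carbon. Little readable range remains for any further weakening: the limit of > 4000000 nM in this assay, at which 2 of the 4 values shown sit.

As far as these compounds go, whether bromo, methoxy or an amine at the same carbon would match chloro or hydroxy remains open. So does whether the shift depends on the hydroxy itself or on the absence of chloro.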